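A Methyl on the Amine, Tried on a Second Core

The source may report more compounds than this note shows. Statements on the series, on what has been measured and on what is new or still open speak of the compounds shown alone.

Compound 1, `CC[C@H](N)C(=O)N[C@@H]1C(=O)N2[C@@H](CC[C@@H]1CCN)CC[C@H]2C(=O)NC(c1ccccc1)c1ccccc1`, in a functional assay on MDA-MB-231 cells (Homo sapiens) for cytotoxicity, read by MTT assay, with a stated time of 96 h (a lower number here means a stronger inhibitor, a higher number a weaker inhibitor), gives 12900 nM.
Compound 2, `CC[C@H](NC)C(=O)N[C@@H]1C(=O)N2[C@@H](CC[C@@H]1CCN)CC[C@H]2C(=O)NC(c1ccccc1)c1ccccc1`, in this assay gives 2300 nM.
Compound 3, `CC[C@H](N)C(=O)N[C@@H]1C(=O)N2[C@@H](CC[C@@H]1CCNC(=O)NCc1ccccc1)CC[C@H]2C(=O)NC(c1ccccc1)c1ccccc1`, in this assay gives 10800 nM.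

Compound 2 differs from compound 1 by a single change, (methyl in place of hydrogen on an amine nitrogen). That change produced a 5.6-fold lower number from compound 1 to compound 2 (0.75 log units; beyond the scatter), a step beyond the usual scatter of the assay, so compound 2 is the stronger inhibitor of the pair.

Compound 3 carries the same amine that is methylated in compound 2, but on a different core: compound 3 differs from compound 1 by benzylcarbamoyl in place of hydrogen on an amine nitrogen. That change left activity essentially where it was, a 1.2-fold lower number from compound 1 to compound 3 (0.08 log units; within the scatter), a step inside the scatter, so compound 1 and compound 3 cannot be ranked against each other.

Compound 4, `CC[C@H](NC)C(=O)N[C@@H]1C(=O)N2[C@@H](CC[C@@H]1CCNC(=O)NCc1ccccc1)CC[C@H]2C(=O)NC(c1ccccc1)c1ccccc1`, has not been measured. It differs from compound 3 by methyl in place of hydrogen on an amine nitrogen. The place of this change is the same, word for word, as the place of the change from compound 1 to compound 2: an amine nitrogen whose other neighbour is a saturated chain carbon. Only the core, which carries the benzylcarbamoyl group in compound 3 and compound 4, is different.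

Within the data shown here, the expectation for compound 4 is therefore built on compound 3 and on the one measured example of the same change. Because a 5.6-fold lower number from compound 1 to compound 2 (0.75 log units; beyond the scatter) was a clear gain, and because a 1.2-fold lower number from compound 1 to compound 3 (0.08 log units; within the scatter) shows that the core difference itself changed little, the step from compound 3 to compound 4 is expected to be similar in size, a 4.7-fold lower number from compound 3 to compound 4 (0.67 log units; beyond the scatter). On that basis compound 4 is estimated to give 2300 nM in this assay, most likely between 900 nM and 6000 nM. The estimate rests on a single precedent, so the true value may deviate.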

Compound 4, half-maximal inhibitory concentration: 1200 nM
Estimate against measurement, compound 4: 1.9-fold (0.28 log units) above, and the stated range covers the measured number.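

In this assay, methyl in place of hydrogen on the amine nitrogen gave a 9.0-fold lower number from compound 3 to compound 4 (0.95 log units; beyond the scatter), and this new step agrees with the earlier one on the other core: the same change on two cores in this assay, a 5.6-fold lower number (0.75 log units; beyond the scatter) from compound 1 to compound 2 and a 9.0-fold lower number (0.95 log units; beyond the scatter) from compound 3 to compound 4, 1.6-fold (0.21 log units) apart, within the scatter of two such steps. The benzylcarbamoyl group, compared on the methylated compounds, gave a 1.9-fold lower number from compound 2 to compound 4 (0.28 log units; within the scatter), a step inside the scatter that leaves compound 2 and compound 4 unranked and matches what the same group did on the compounds without the methyl: the same change on two cores in this assay, a 1.2-fold lower number (0.08 log units; within the scatter) from compound 1 to compound 3 and a 1.9-fold lower number (0.28 log units; within the scatter) from compound 2 to compound 4, 1.6-fold (0.21 log units) apart, within the scatter of two such steps. Together these two comparisons show that the gain from the methyl carried over from one core to the other, with neither core giving a step that can be told apart from the other, but they rest on just two matched pairs in a single cell assay and do not show why the methyl helps or whether the gain would hold on any further core.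

The compounds shown leave open whether an ethyl group, a longer chain or a second methyl on that amine nitrogen would keep the gain. They also leave open whether the step survives when the benzylcarbamoyl group gives way to another group, such as an acetyl group or a carboxylic acid.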